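Benzanilide acids at the bile acid receptor: phenyl for pentyloxy

The source may hold more compounds than are shown below. What is called first, only, known or untested is meant among the compounds shown, and "the series" means these compounds.

Within the data shown here, compound 3 `CCCCCOc1cccc(C(=O)Nc2cccc(C(=O)O)c2)c1` is the one member of this small set with a numerical read-out in an assay on isolated protein for agonist activity at Bile acid receptor (Homo sapiens), read by TR-FRET, with a stated time of 3 h, in the absence of a further agent; on this read-out lower numbers stand for an effect already at smaller amounts and higher numbers for an effect only at larger amounts of compound: compound 3 gives 2540 nM. Compound 1 `CC(Oc1cccc(NC(=O)c2ccc(Oc3ccccc3)cc2)c1)C(=O)O` reaches only a limit of this assay, > 10000 nM. Compound 2 `Cc1ccc(NC(=O)c2cccc(C(=O)O)c2)cc1` likewise sits at a limit of this assay, > 10000 nM. Two of the three results thus coincide at the limit of > 10000 nM in this assay, at which 2 of the 3 values shown sit, and compound 3 stands alone as the only measurable point; nothing about the size of its distance from the two limits can be said beyond the fact that its number lies inside the range of the assay.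

The next compound, compound 4 `O=C(O)c1cccc(NC(=O)c2cccc(-c3ccccc3)c2)c1`, differs from compound 3 in one place: phenyl in place of pentyloxy on an aromatic carbon, meta to a large group. Among the measured compounds shown here, no measured pair in the set shares this change, so the size of the step cannot be read from the data. The expected step is a 1.6-fold higher number from compound 3 to compound 4 (0.20 log units; within the scatter), modest and toward weaker activity, the reasoning resting only on compound 3 at 2540 nM as the single anchor and on the limit of > 10000 nM in this assay, at which 2 of the 3 values shown sit, being where the other two compounds end. Compound 4 is therefore estimated at 4000 nM in this assay, within 1200 nM to 15000 nM.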

Compound 4, half-maximal effective concentration: 25 nM
Compound 4: middle estimate off by 160-fold (2.20 log units), on the high side, and the stated range ends above it.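

The exchange of pentyloxy for phenyl on an aromatic carbon, meta to a large group, gives a 100-fold lower number from compound 3 to compound 4 (2.01 log units; beyond the scatter) in this assay. Among these compounds, compound 3 alone showed only that a measurable number is possible with pentyloxy at this place; the pair now shows that the read-out is highly sensitive to the group that stands there. Both groups have the same count of heavy atoms, so within this pair that count does not set the read-out, while the ring enters and the hydrogen-bond acceptor of pentyloxy leaves in the same change.

On these data alone, the pair cannot separate the entering ring from the leaving oxygen, and it remains open whether a cyclohexyl group, which keeps a ring of the same size without aromaticity, or a pyridyl group, which puts a ring nitrogen into the aromatic ring, would keep the lower number at this carbon. Compounds 1 and 2 offer no further step on this question, and their results stay limits rather than numbers: the limit of > 10000 nM in this assay, at which 2 of the 4 values shown sit.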